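Replacing a Small Ring With an Open Chain

The source may hold more compounds than are shown below. What is called first, only, known or untested is meant among the compounds shown, and "the series" means these compounds.

Of the compounds shown here, two have so far been tested in a functional assay on the whole organism with Mus musculus as the target, at a dose of 100 mg/kg by the intraperitoneal route; on this read-out higher numbers stand for more inhibition at the one dose given (going by the name of the read-out) and lower numbers for less inhibition. Compound 1, `O=C(/C=C1\CCc2cc(Cl)ccc21)NC1CC1`, gives 17% in this assay. Compound 2, `O=C(/C=C1\CCc2ccc(F)cc21)NCC1CC1`, gives 50% in this assay, the higher of the two numbers, and its gap to compound 1 lies beyond the usual scatter of repeated measurements. Compound 3, `CCCNC(=O)/C=C1\CCc2ccc(F)cc21`, has not yet been measured. It differs from compound 2 in one place: ethyl in place of cyclopropyl on a saturated chain carbon bound to an amide-type nitrogen. Within the data shown here, no pair of measured compounds shows what this change does on its own, so the direction of the step can only be estimated. A small move downward, or no change beyond the scatter, seems most plausible, and a step of a number 10 percentage points lower from compound 2 to compound 3 (within the scatter) is expected. Compound 3 is accordingly estimated to give 40% in this assay, with a likely range from 15% to 65%.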

Compound 3, a percentage reported as inhibition, in the whole organism at one dose (the size of the read-out at that dose, not a potency): 100%
Compound 3: middle estimate off by 60 percentage points, on the low side, and the stated range ends below it.
By their numbers in this assay, from the lowest: compound 1; then compound 2; then compound 3.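

In this assay, ethyl in place of cyclopropyl on a saturated chain carbon bound to an amide-type nitrogen gives a number 50 percentage points higher from compound 2 to compound 3 (beyond the scatter), so the group at this position matters a great deal. The three-membered ring is not needed for a high read-out here, and the open propyl chain does far better than cyclopropylmethyl, something compound 1 and compound 2 could not show, as they differ in more than one place. Nothing measured here explains the size of this rise.

From the compounds shown here alone, it remains open whether a longer chain such as butyl, a branched one such as isopropyl, or a chain ending in an amine would hold this level. Going by these compounds, compound 3 gives 100% at a single dose, which is not a potency, so how far the dose could fall with the propyl chain in place also stays unknown.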